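From amino to chloro on a shared core

A few compounds are considered here, and "the series" means these few. Any claim that something is new, unique, unknown or untested is made for them only; others in the source may bear on it.

Measured in an ADME assay on L1210/0 cells (Mus musculus) for cytotoxicity, with a stated time of 48 h; on this read-out higher numbers stand for weaker inhibition and lower numbers for stronger inhibition:
- compound 1 `O=c1[nH]cnc2c1nnn2C1C[C@H](CO)[C@@H](CO)[C@@H]1CO`: > 200000 nM
- compound 2 `Nc1ncnc2c1ncn2[C@@H]1C[C@@H]2COC[C@H]2[C@H]1CO`: > 200000 nM

Neither reading is a number. For compound 1, > 200000 nM is a limit of the assay. For compound 2, > 200000 nM is likewise a limit. As far as these compounds go, compound 2 thus stands at the limit of > 200000 nM in this assay, at which 2 of the 2 values shown sit, and its true value remains unknown.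

Compound 3 `OC[C@@H]1[C@@H]2COC[C@H]2C[C@H]1n1cnc2c(Cl)ncnc21` keeps the core of compound 2 and differs in one place: chloro in place of amino on an aromatic carbon. The exchange lies on an aromatic carbon of a six-membered aromatic ring with 2 nitrogen, part of a fused or bridged system of two rings.

Going by the values given here, no measured pair here shows what such an exchange does, so the expectation is only tentative. A modest move in this assay toward lower numbers, meaning stronger inhibition, is expected, though compound 3 may equally return only a limit. The estimated change is an at least 2.0-fold lower number from compound 2 to compound 3 (0.30 log units; that floor lies within the scatter). For compound 3 the estimated value is 100000 nM, with an expected range from 25000 nM to 200000 nM.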

Compound 3, half-maximal inhibitory concentration: > 200000 nM
Compound 3 ended at the assay's limit; the forecaster's own chance of this, stated with the estimate: 50%; middle value at least 2.0-fold (0.30 log units) away from the limit.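

In this assay compound 3 gives > 200000 nM, which is a limit and not a number. Compound 2 also stands at a limit, so no step from amino to chloro can be read between compound 2 and compound 3: the limit of > 200000 nM in this assay, at which 3 of the 3 values shown sit.

The compounds shown leave open whether this exchange changes inhibition at all.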